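Bromine on the Phenyl Ring of Compound 1

The compounds below may be only part of what the source reports. "The series", "measured", "known", "first", "only" and "open" are said of these compounds alone.

Compound 1 `COC(=O)c1c(-c2cc3ccccc3oc2=O)nn(-c2ccccc2)c1C(=O)OC` is one of three measured compounds built on a shared core. In a functional assay on DU-145 cells (Homo sapiens) for cytotoxicity, read by MTT assay, with a stated time of 48 h (a lower number here means a stronger inhibitor, a higher number a weaker inhibitor), compound 1 gives 30000 nM. Compound 2 `CCOC(=O)c1c(-c2cc3ccccc3oc2=O)nn(-c2cccc(C)c2)c1C(=O)OCC` gives 47000 nM, and compound 3 `CCOC(=O)c1c(-c2cc3ccccc3oc2=O)nn(-c2cccc(F)c2)c1C(=O)OCC` gives 32000 nM. Compound 1 has the lowest of the three numbers, but its gaps to compound 3 and to compound 2 both lie within the scatter, so the three cannot be ranked against one another. For the measured compounds named here, the only measured step, a 1.5-fold lower number from compound 2 to compound 3 (0.17 log units; within the scatter), exchanges one substituent on the pendant phenyl ring for another and also stays within the scatter.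

Compound 4 `COC(=O)c1c(-c2cc3ccccc3oc2=O)nn(-c2ccc(Br)cc2)c1C(=O)OC` differs from compound 1 by bromo in place of hydrogen on an aromatic carbon. Going by the values given here, no measured pair places a bromo on this ring, and the position changed here was not varied among compound 2 and compound 3, so the bearing of the measured step is indirect: it shows only that a small substituent on that ring left this assay unmoved. Compound 4 is therefore expected to sit close to compound 1, with an expected step of no change at the digits printed from compound 1 to compound 4 (within the scatter). The estimate for compound 4 is 30000 nM, expected between 12000 nM and 75000 nM.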

Compound 4, half-maximal inhibitory concentration: 93000 nM
The estimate for compound 4 lay 3.1-fold (0.49 log units) below the measured number; measured number outside the range, above it.
By their numbers in this assay, from the lowest: compounds 1, 3, 2 and 4 (each within the scatter of the next, the first and the last beyond it).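

Replacing phenyl with 4-bromophenyl gives a 3.1-fold higher number from compound 1 to compound 4 (0.49 log units; beyond the scatter) in this assay, so this change on the pendant ring moves the number beyond the scatter, which the step between the two earlier substituted compounds did not do. The change places bromo on an aromatic carbon, para to a large group, and compound 4 is a modestly weaker inhibitor than compound 1, which carries hydrogen there. The compounds shown offer no measurement that accounts for this step.

They leave open whether the step belongs to bromo in particular or would also appear with another group on this carbon, such as an amine or a carboxylic acid. They also leave open whether bromo on the ring carbon that carries methyl in compound 2 and fluoro in compound 3 would produce a step of similar size.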